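Amide aryl swap on the shared core: toward the nitro analogue

This account rests on a few compounds, and the source may have more. Where it says the series, first, only, none or still open, it means among the compounds named here.

Compound 1 `Cc1ccc(NC(=O)c2ccc(/N=N\c3c[nH]c4ccccc34)cc2)c(C)c1` gives the highest number of the three measured compounds in a functional assay on P388 cells (Mus musculus) for inhibition, read by MTT assay, with a stated time of 72 h (a higher number here means a weaker inhibitor, a lower number a stronger inhibitor), namely 190000 nM. Compound 2 `O=C(Nc1ccccc1F)c1ccc(/N=N\c2c[nH]c3ccccc23)cc1` gives 106000 nM in this assay, and compound 3 `O=C(Nc1ccc(Cl)cc1)c1ccc(/N=N\c2c[nH]c3ccccc23)cc1` gives 80000 nM in this assay. The change a 1.8-fold lower number from compound 1 to compound 2 (0.25 log units; within the scatter) stays within the scatter, while a 2.4-fold lower number from compound 1 to compound 3 (0.38 log units; beyond the scatter) is a modest step beyond it; the pair a 1.3-fold lower number from compound 2 to compound 3 (0.12 log units; within the scatter) is within the scatter. Compound 4 `O=C(Nc1cccc([N+](=O)[O-])c1)c1ccc(/N=N\c2c[nH]c3ccccc23)cc1` has not been measured. It differs from compound 1 in one place: 3-nitrophenyl in place of 2,4-dimethylphenyl on an amide-type nitrogen. For the measured compounds named here, both measured steps that replace the 2,4-dimethylphenyl on the amide-type nitrogen point toward a lower number in this assay, one within the scatter and one modestly beyond it, and no measured step covers a nitro-bearing ring. The expectation for compound 4 is therefore a lower number than compound 1, of about the size seen in a 2.4-fold lower number from compound 1 to compound 3 (0.38 log units; beyond the scatter), meaning an expected step of a 1.9-fold lower number from compound 1 to compound 4 (0.28 log units; within the scatter). Compound 4 is estimated at 100000 nM in this assay, expected to fall between 40000 nM and 250000 nM.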

Compound 4, half-maximal inhibitory concentration: 51900 nM
For compound 4 the middle estimate is 1.9-fold (0.28 log units) above the measured one, within the range that was stated.
By their numbers in this assay, from the lowest: compounds 4, 3, 2 and 1 (each within the scatter of the next, the first and the last beyond it).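

In this assay, a ring carrying a nitro group on the amide-type nitrogen also replaces the 2,4-dimethylphenyl without reversing the direction seen so far, with a 3.7-fold lower number from compound 1 to compound 4 (0.56 log units; beyond the scatter), so the position tolerates a group with hydrogen-bond acceptors as well as the halogen-bearing rings. The 3-nitrophenyl also separates modestly from the 2-fluorophenyl, with a 2.0-fold lower number from compound 2 to compound 4 (0.31 log units; beyond the scatter), but not from the 4-chlorophenyl, with a 1.5-fold lower number from compound 3 to compound 4 (0.19 log units; within the scatter), so the 3-nitrophenyl and 4-chlorophenyl rings cannot be ranked here. No measurement shown offers an explanation for these steps.

As far as these compounds go, whether an amine or a carboxylic acid on this phenyl ring would continue the same direction remains open. Also open, from the compounds shown here alone, is whether the step belongs to the nitro group itself or would survive with a nitrile in its place.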